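Amide substituent notes: cyclohexyl to isopropyl

The compounds below may be only part of what the source reports. "The series", "measured", "known", "first", "only" and "open" are said of these compounds alone.

In a physicochemical assay for solubility, at pH 6.8 (on this read-out lower numbers stand for lower solubility and higher numbers for higher solubility), compound 1 (`CN(C)Cc1ccc(-c2cnc(N)c(C(=O)NC3CCCC3O)n2)cc1`) gives 940000 nM, compound 2 (`CN(C)Cc1ccc(-c2cnc(N)c(C(=O)NC[C@@](C)(O)C(F)(F)F)n2)cc1`) gives 510000 nM and compound 3 (`CN(C)Cc1ccc(-c2cnc(N)c(C(=O)NC3CCCCC3)n2)cc1`) gives 190000 nM, the lowest of the three numbers. Compound 4 (`CC(C)NC(=O)c1nc(-c2ccc(CN(C)C)cc2)cnc1N`) carries isopropyl in place of cyclohexyl on an amide-type nitrogen. Among the measured compounds shown here, two measured steps bear on this position, both modest and both ending at cyclohexyl: a 4.9-fold lower number from compound 1 to compound 3 (0.69 log units; beyond the scatter) and a 2.7-fold lower number from compound 2 to compound 3 (0.43 log units; beyond the scatter). For the measured compounds named here, no measured step exchanges cyclohexyl for a smaller carbon-only group, so this evidence is indirect. A modest upward move in this assay is expected, estimated as a 2.1-fold higher number from compound 3 to compound 4 (0.32 log units; beyond the scatter). Compound 4 is estimated at 400000 nM, with an expected range of 190000 nM to 850000 nM.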

Compound 4, solubility: > 1000000 nM
Compound 4 ended at the assay's limit; the forecaster's own chance of this, stated with the estimate: 10%; at least 2.5-fold (0.39 log units) between middle value and limit.
By their numbers in this assay, from the lowest: compound 3; then compounds 2 and 1 (each within the scatter of the next). At a limit, above all of these: compound 4.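

In this assay compound 4 reads > 1000000 nM, which is a limit of the assay and not a number. Isopropyl in place of cyclohexyl gives an at least 5.2-fold higher number from compound 3 to compound 4 (0.72 log units; beyond the scatter), so a carbon-only group at this position, with no hydroxy substituent, need not sit at the low end of the series. Against the hydroxy-bearing groups, the floors are an at least 1.9-fold higher number from compound 2 to compound 4 (0.29 log units; that floor lies within the scatter) and an at least 1.0-fold higher number from compound 1 to compound 4 (0.02 log units; that floor lies within the scatter), so no order can be stated.

As far as these compounds go, whether cyclopentyl, tert-butyl or a longer alkyl chain on this nitrogen tracks isopropyl or cyclohexyl stays open. The true size of all three steps also stays open: the limit of > 1000000 nM in this assay, at which 1 of the 4 values shown sits.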